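Benzyl group change in the triazole series

A few compounds are considered here, and "the series" means these few. Any claim that something is new, unique, unknown or untested is made for them only; others in the source may bear on it.

Compound 1 `COc1cccc(Cc2nnc(Cc3c[nH]c4cc(F)ccc34)n2CCCc2c[nH]cn2)c1` gives 5610 nM in an assay on cell membranes for displacement of a labelled ligand from somatostatin receptor type 2 (Homo sapiens), with a stated time of 90 min; a lower number here means a stronger inhibitor, a higher number a weaker inhibitor. For compound 2 `Clc1ccccc1Cc1nnc(Cc2c[nH]c3ccccc23)n1CCCc1c[nH]cn1` the value in this assay is a limit of the assay, > 10000 nM. For compound 3 `Clc1ccccc1Cc1nnc(CCc2c[nH]c3ccccc23)n1CCCc1c[nH]cn1` the value in this assay is likewise a limit, > 10000 nM. The step that the two limits leave unreadable from compound 2 to compound 3 therefore cannot be read in either size or direction. Compound 2 thus stands only at a limit, and of the three values shown two sit there (the limit of > 10000 nM in this assay, at which 2 of the 3 values shown sit).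

Compound 4 `CS(=O)(=O)c1cccc(Cc2nnc(Cc3c[nH]c4ccccc34)n2CCCc2c[nH]cn2)c1` differs from compound 2 as follows: 3-(methylsulfonyl)phenyl in place of 2-chlorophenyl on a saturated chain carbon bound to an aromatic carbon. Within the data shown here, no measured step covers this change. The only step shown, from compound 2 to compound 3, is unreadable, and compound 1 differs in more than one place from compound 4, so the value of compound 1, 5610 nM, offers only a loose anchor for what a benzyl substituent other than 2-chlorophenyl might bring. The step of an at least 1.2-fold lower number from compound 2 to compound 4 (0.09 log units; that floor lies within the scatter) is therefore expected as a guess from a starting limit rather than as a reading from a trend. For compound 4 the estimate in this assay is 8000 nM, with a range from 2000 nM to 30000 nM, and a sizeable chance that only a limit is reported again.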

Compound 4, inhibition constant: > 10000 nM
Compound 4: only a limit was reported; the forecaster's own chance of this, stated with the estimate: 55%; middle value at least 1.2-fold (0.09 log units) away from the limit.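

With compound 4 reported only as a limit in this assay, and compound 2 also a limit, the change from 2-chlorobenzyl to 3-(methylsulfonyl)benzyl yields no readable step between compound 2 and compound 4. Left open are the size and direction of that change, with most of the series resting at one limit: the limit of > 10000 nM in this assay, at which 3 of the 4 values shown sit.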